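The source may hold more compounds than are shown below. What is called first, only, known or untested is meant among the compounds shown, and "the series" means these compounds.

Measured compounds:
Compound 1, `CN(Cc1cn(CC(O)COC(=O)c2ccccc2)nn1)CC1CCCCC1`, 6%
Compound 2, `CN(CCCc1ccccc1)Cc1cn(CC(O)COCc2ccccc2)nn1`, 18%

In an assay on nucleic acid for inhibition of Nucleic Acid, read by fluorescence, tested at 100 uM (a lower number here means less inhibition, a higher number more inhibition at the concentration tested (going by the name of the read-out)), compound 2 stands highest of the two, and compound 1 sits lower by a gap beyond the usual scatter. Compound 3, `CN(Cc1cn(CC(O)COCc2ccccc2)nn1)CC1CCCCC1`, has not yet been measured. It differs from compound 2 in one place: cyclohexyl in place of phenethyl on a saturated chain carbon bound to an amine nitrogen. Going by the values given here, no measured pair shows exactly this change, so the size of the step in this assay is open. Compound 3 shares the cyclohexyl group of compound 1, which gives 6%, so a modest downward step is expected, a number 7 percentage points lower from compound 2 to compound 3 (within the scatter). For compound 3 the estimate is 11%, within 0% to 24%.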

Compound 3, a percentage reported as inhibition, at one concentration (the size of the read-out at that concentration, not a potency): 6%
For compound 3 the middle estimate is 5 percentage points above the measured one; the range from low to high includes it.
By their numbers in this assay, from the lowest: compounds 1 and 3 (each within the scatter of the next); then compound 2.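

In this assay, going by these compounds alone, cyclohexyl in place of phenethyl on a saturated chain carbon bound to an amine nitrogen gives a number 12 percentage points lower from compound 2 to compound 3 (beyond the scatter), the first reading of this change at this position. Benzyl in place of benzoyl on an oxygen on a saturated carbon gives no change at the digits printed from compound 1 to compound 3 (within the scatter), so that change leaves the read-out unmoved within the scatter. No measurement here explains either result. On these data alone, the change at the amine replaces the aromatic ring and alters the chain together, so the effect of each alone remains open. A 3-cyclohexylpropyl group or a benzyl group on that nitrogen could separate them.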